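The source may report more compounds than this note shows. Statements on the series, on what has been measured and on what is new or still open speak of the compounds shown alone.

Among the measured compounds shown here, the three compounds measured so far share one core and differ only in the group on an oxygen on a saturated carbon. Compound 1 `CC(C)c1cc(OCC(=O)[C@H](CC(=O)O)NC(=O)[C@@H](NC(=O)COc2cccc3ccccc23)C(C)C)no1` carries a 5-isopropyl-1,2-oxazol-3-yl group there. In a functional assay on Jurkat cells (Homo sapiens) for inhibition (on this read-out lower numbers stand for stronger inhibition and higher numbers for weaker inhibition), compound 1 reaches only a limit of the measurement, > 200000 nM. Compound 2 `Cc1cc(OCC(=O)[C@H](CC(=O)O)NC(=O)[C@@H](NC(=O)COc2cccc3ccccc23)C(C)C)nc(C)n1` carries a 2,6-dimethylpyrimidin-4-yl group instead, and in this assay compound 2 also gives only a limit, > 200000 nM. Compound 3 `CC(C)[C@H](NC(=O)COc1cccc2ccccc12)C(=O)N[C@@H](CC(=O)O)C(=O)COc1cccc2cccnc12` carries a quinolin-8-yl group, and in this assay compound 3 likewise gives only a limit, > 200000 nM. Compound 3 therefore has no number of its own to stand on; it sits at the limit of > 200000 nM in this assay, at which 3 of the 3 values shown sit. The steps between the measured compounds are accordingly unreadable: a step that the two limits leave unreadable from compound 1 to compound 2, a step that the two limits leave unreadable from compound 1 to compound 3 and a step that the two limits leave unreadable from compound 2 to compound 3.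

Compound 4 `CC(C)[C@H](NC(=O)COc1cccc2ccccc12)C(=O)N[C@@H](CC(=O)O)C(=O)COc1cc2ccccc2cn1` has not been measured. It differs from compound 3 by isoquinolin-3-yl in place of quinolin-8-yl on an oxygen on a saturated carbon; the two hold the same atoms, joined differently. For the measured compounds named here, no measured step gives a readable size for a change of this kind; every step among the measured compounds ends at a limit, so no direction can be read from them. Compound 4 is therefore expected to stay at the limit as well, with an estimated value of 200000 nM, between 50000 nM and 400000 nM. The expected step from compound 3 is then a number no higher from compound 3 to compound 4 (the limit leaves the size open).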

Compound 4, half-maximal inhibitory concentration: > 200000 nM
Compound 4: a limit, no number (the forecaster's own chance of this, stated with the estimate: 80%); the middle value lies on the limit itself.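

In this assay compound 4 gives only a limit, as do compound 1, compound 2 and compound 3, so no step among these compounds can be read: the limit of > 200000 nM in this assay, at which 4 of the 4 values shown sit. The compounds shown leave open how these four groups compare in this assay and whether any group on this oxygen gives a real number instead of a limit.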